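The source may report more compounds than this note shows. Statements on the series, on what has been measured and on what is new or still open speak of the compounds shown alone.

Measured compounds:
compound 1 `O=C(/C=C/C(=O)N1C/C(=C\c2ccc([N+](=O)[O-])cc2)C(=O)/C(=C/c2ccc([N+](=O)[O-])cc2)C1)Nc1ccc(Cl)c(Cl)c1` — in a functional assay on Molt4/C8 cells (Homo sapiens) for cytotoxicity (a lower number here means a stronger inhibitor, a higher number a weaker inhibitor), compound 1 gives 600 nM;
compound 2 `O=C(/C=C/C(=O)N1C/C(=C\c2ccc([N+](=O)[O-])cc2)C(=O)/C(=C/c2ccc([N+](=O)[O-])cc2)C1)Nc1ccc(Cl)cc1` — in this assay compound 2 gives 1200 nM.

Compound 2 stands beside compound 1 rather than apart from it, since a 2.0-fold higher number from compound 1 to compound 2 (0.30 log units; within the scatter). Compound 3 `Cc1cccc(C)c1NC(=O)/C=C/C(=O)N1C/C(=C\c2ccc([N+](=O)[O-])cc2)C(=O)/C(=C/c2ccc([N+](=O)[O-])cc2)C1` carries 2,6-dimethylphenyl in place of 4-chlorophenyl on an amide-type nitrogen. Within the data shown here, no measured step touches this exchange: the only step known, a 2.0-fold higher number from compound 1 to compound 2 (0.30 log units; within the scatter), concerns a chloro and stays within the scatter. The author therefore expects no step beyond the scatter in this assay for compound 3, and estimates compound 3 at 1200 nM, within 400 nM to 3600 nM, an expected step of no change at the digits printed from compound 2 to compound 3 (within the scatter).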

Compound 3, half-maximal inhibitory concentration: 210 nM
For compound 3 the middle estimate is 5.7-fold (0.76 log units) above the measured one; the whole stated range lies above it.
By their numbers in this assay, from the lowest: compound 3; then compounds 1 and 2 (each within the scatter of the next).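

At the amide-type nitrogen, the aryl group does make a difference in this assay: 2,6-dimethylphenyl gives a 5.7-fold lower number from compound 2 to compound 3 (0.76 log units; beyond the scatter) and, against 3,4-dichlorophenyl, a 2.9-fold lower number from compound 1 to compound 3 (0.46 log units; beyond the scatter). Among these compounds, the chloro step alone had stayed within the scatter, so only this exchange of the whole aryl group shows that the position responds beyond it. No evidence here explains the change.

Compound 3 loses the chloro and gains both methyl groups at once, so the compounds shown do not separate these changes. Going by these compounds, how a cyclohexyl group or a pyridyl ring would fare on this nitrogen also stays open.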